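A few compounds are considered here, and "the series" means these few. Any claim that something is new, unique, unknown or untested is made for them only; others in the source may bear on it.

Measured in an ADME assay on HepG2 cells (Homo sapiens) for cytotoxicity, read by MTT assay, with a stated time of 72 h; a higher number here means that more compound is tolerated, a lower number that less compound is tolerated
- compound 1 `CC(C)(C)Nc1nc2cc(-c3ccc(F)cc3)sc2c(=O)[nH]1` gives 5100 nM
- compound 2 `CC(C)Nc1nc2cc(-c3ccc(Cl)cc3)sc2c(=O)[nH]1` gives > 15600 nM

Compound 2 stands at > 15600 nM as a limit of the assay and not a number. Compound 3 `CC(C)Nc1nc2cc(-c3ccc(F)cc3)sc2c(=O)[nH]1` has fluoro in place of chloro on an aromatic carbon and so goes from 4-chlorophenyl to 4-fluorophenyl. Going by the values given here, no measured pair shows this change alone. In this assay no step beyond the scatter is expected, and the estimated at least 1.1-fold lower number from compound 2 to compound 3 (0.04 log units; that floor lies within the scatter) is small. Compound 1 at 5100 nM shows that a measured number can occur in this series. For compound 3 the expected value is 14000 nM within an estimated range from 5000 nM to 30000 nM in this assay.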

Compound 3, half-maximal cytotoxic concentration: > 25000 nM
Compound 3 gave a limit, no number; the forecaster's own chance of this, stated with the estimate: 45%; middle value at least 1.7-fold (0.25 log units) from the limit.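

In this assay compound 3 gives > 25000 nM, a limit of the assay and not a number. The step from 4-chlorophenyl to 4-fluorophenyl cannot be read, as compound 2 and compound 3 both stand at limits. Hydrogen in place of methyl on the saturated chain carbon gives an at least 4.9-fold higher number from compound 1 to compound 3 (0.69 log units; beyond the scatter), the first readable step in this series and one that places the sensitivity in the chain, with the 4-fluorophenyl group held constant.

Open, going by these compounds, is how a longer chain or a chain ending in an amine would read in this assay. Also open, on these data alone, is whether chloro and fluoro differ at all once numbers replace the limits.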